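Removing the Second Methoxy: Notes Toward Compound 3

The source may report more compounds than this note shows. Statements on the series, on what has been measured and on what is new or still open speak of the compounds shown alone.

Measured so far in a functional assay on MDA-MB-231 cells (Homo sapiens) for cytotoxicity, read by crystal violet staining, with a stated time of 72 h; on this read-out higher numbers stand for weaker inhibition and lower numbers for stronger inhibition:
- compound 1 `COc1cc(/C=C/C(=O)/C=C(O)/C=C/c2ccc(O[C@H]3C=C(C)[C@@H](O)C[C@@H]3[C@@H](C)CC(=O)C=C(C)C)c(OC)c2)ccc1O` gives 10600 nM
- compound 2 `COc1cc(/C=C/C(O)=C/C(=O)/C=C/c2ccc(O)cc2)ccc1O[C@H]1C=C(C)[C@@H](O)C[C@@H]1[C@@H](C)CC(=O)C=C(C)C` gives 10300 nM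

The two numbers fall within the scatter of each other, so compound 2 cannot be set apart from compound 1 in this assay.

Compound 3 `CC(C)=CC(=O)C[C@H](C)[C@H]1C[C@H](O)C(C)=C[C@@H]1Oc1ccc(/C=C/C(O)=C/C(=O)/C=C/c2ccc(O)cc2)cc1` differs from compound 2 by hydrogen in place of methoxy on an aromatic carbon. Among the measured compounds shown here, the one step already seen of this same kind, a 1.0-fold lower number from compound 1 to compound 2 (0.01 log units; within the scatter), stayed within the scatter. On that basis no step beyond the scatter is expected in this assay, the anticipated change being no change at the digits printed from compound 2 to compound 3 (within the scatter). Compound 3 is therefore estimated at 10300 nM, with a range of 5000 nM to 21000 nM.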

Compound 3, half-maximal inhibitory concentration: 30800 nM
Compound 3: middle estimate off by 3.0-fold (0.48 log units), on the low side, outside the stated range (above it).
By their numbers in this assay, from the lowest: compounds 2 and 1 (each within the scatter of the next); then compound 3.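

In this assay, hydrogen in place of methoxy does not behave alike at both methoxy groups: the loss of the remaining methoxy gives a 3.0-fold higher number from compound 2 to compound 3 (0.48 log units; beyond the scatter) and moves beyond the scatter, whereas the loss of the other gave a 1.0-fold lower number from compound 1 to compound 2 (0.01 log units; within the scatter) and stayed within it. The outcome of this change therefore depends on which methoxy leaves. No available evidence accounts for the difference. The compounds shown leave open whether a group other than methoxy or hydrogen at this position, such as an amine or a chlorine atom, would keep the number near that of compound 2.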